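Swapping the Pyrazolylamino Group for a Methylpyridyl Ring

The source may report more compounds than this note shows. Statements on the series, on what has been measured and on what is new or still open speak of the compounds shown alone.

Measured compounds:
- compound 1, `CN(c1ccn(C)n1)c1cnc(NCc2c(F)ccc3c2CCO3)c2cn[nH]c(=O)c12`: 62 mL.min-1.g-1
- compound 2, `O=C1CCCN1c1cnc(NCc2c(F)ccc3c2CCO3)n2cnnc12`: < 3 mL.min-1.g-1
- compound 3, `C[C@@H]1CC(=O)N(c2cnc(NCc3c(F)ccc4c3CCO4)n3cnnc23)C1`: < 3 mL.min-1.g-1

Going by the values given here, compound 1, `CN(c1ccn(C)n1)c1cnc(NCc2c(F)ccc3c2CCO3)c2cn[nH]c(=O)c12`, is the only compound of the three that returns a number in an ADME assay on microsomes from liver (Homo sapiens) for metabolic stability, read by LC-MS, using NADPH, with stated times of 5 min and 30 min, tested at 1 uM (on this read-out higher numbers stand for fast clearance and lower numbers for slow clearance), where compound 1 gives 62 mL.min-1.g-1. The other two values are limits of the assay. For compound 2, `O=C1CCCN1c1cnc(NCc2c(F)ccc3c2CCO3)n2cnnc12`, the read-out is the limit < 3 mL.min-1.g-1. For compound 3, `C[C@@H]1CC(=O)N(c2cnc(NCc3c(F)ccc4c3CCO4)n3cnnc23)C1`, the read-out is likewise the limit < 3 mL.min-1.g-1. Among the compounds with values here, the one step between measured compounds, a step that the two limits leave unreadable from compound 2 to compound 3, is on a different core from compound 1 and its size cannot be read, because of the limit of < 3 mL.min-1.g-1 in this assay, at which 2 of the 3 values shown sit.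

Compound 4, `Cc1ncccc1-c1cnc(NCc2c(F)ccc3c2CCO3)c2cn[nH]c(=O)c12`, differs from compound 1 in one place: 2-methylpyridin-3-yl in place of methyl(1-methyl-1H-pyrazol-3-yl)amino on an aromatic carbon. Within the data shown here, no measured step involves this change or this position on the shared core, so there is nothing to read a direction from. Compound 4 is therefore expected to sit near compound 1 in this assay, with a wide allowance either way: an estimated step of a 1.4-fold lower number from compound 1 to compound 4 (0.14 log units; within the scatter). The estimate for compound 4 is 45 mL.min-1.g-1, within the range 12 mL.min-1.g-1 to 130 mL.min-1.g-1.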

Compound 4, intrinsic clearance in microsomes: 41 mL.min-1.g-1
Compound 4: middle estimate off by 1.1-fold (0.04 log units), on the high side; the range from low to high includes it.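

Going by these compounds alone, replacing methyl(1-methyl-1H-pyrazol-3-yl)amino with 2-methylpyridin-3-yl on this aromatic carbon of the shared core gives the only readable step in this assay, namely a 1.5-fold lower number from compound 1 to compound 4 (0.18 log units; within the scatter). This position therefore accepts a six-membered aromatic ring with 1 hetero atom in place of an amino-linked five-membered aromatic ring with 2 hetero atoms, and the hydrogen-bond acceptors of the group go from 3 to 1, with no change in this read-out beyond the scatter. Nothing measured here accounts for why the read-out holds across so large a swap of groups.

Whether this holds for other groups on the same carbon stays open, since a plain pyridin-3-yl without the methyl, a morpholine or a carboxylic acid does not appear among the compounds shown, and one step at one position cannot show which part of the 2-methylpyridin-3-yl group matters. The step from compound 2 to compound 3 cannot be read and lies on a different core, so it adds nothing on this question.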